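Replacing phenyl with (1-methylcyclopropyl)methyl on compound 2

The compounds below may be only part of what the source reports. "The series", "measured", "known", "first", "only" and "open" are said of these compounds alone.

Measured in an ADME assay on liver for metabolic stability, with Liver microsome (Homo sapiens) as the target, read by LC-MS, using microsomes; a higher number here means faster removal of the compound, a lower number slower removal:
Compound 1 `O=C(NCc1cc(Cl)ccc1-n1cnnn1)[C@@H]1CC=NN1C(=O)[C@H](O)c1ccccc1F`: 16 mL.min-1.g-1
Compound 2 `O=C(NCc1cc(Cl)ccc1-n1cnnn1)[C@@H]1CC=NN1C(=O)[C@H](O)c1ccccc1`: < 12 mL.min-1.g-1 (a limit)

Compound 2 gives < 12 mL.min-1.g-1 in this assay, and this is a limit of the assay, not a number. It stands at the limit of < 12 mL.min-1.g-1 in this assay, at which 1 of the 2 values shown sits. Compound 3 `CC1(C[C@@H](O)C(=O)N2N=CC[C@H]2C(=O)NCc2cc(Cl)ccc2-n2cnnn2)CC1` differs from compound 2 at one place: (1-methylcyclopropyl)methyl in place of phenyl on a saturated chain carbon bound to a carbonyl carbon and an oxygen on a saturated carbon, on a saturated chain carbon bound to a carbonyl carbon and an oxygen on a saturated carbon.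

Within the data shown here, only one measured step bears on this, and only loosely. With hydrogen in place of fluoro on an aromatic carbon, it runs an at least 1.3-fold lower number from compound 1 to compound 2 (0.12 log units; that floor lies within the scatter), and its floor lies within the scatter. Among the measured compounds shown here, no measured step removes the phenyl itself, so the guide is weak. A small rise in this assay is expected, of about the size of the scatter. The expected change is an at least 1.2-fold higher number from compound 2 to compound 3 (0.09 log units; that floor lies within the scatter). For compound 3 the estimated value is 15 mL.min-1.g-1, with an expected range from 7 mL.min-1.g-1 to 35 mL.min-1.g-1.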

Compound 3, intrinsic clearance in microsomes: < 12 mL.min-1.g-1
Compound 3: only a limit was reported (the forecaster's own chance of this, stated with the estimate: 30%); middle value at least 1.2-fold (0.09 log units) from the limit.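

In this assay compound 3 gives < 12 mL.min-1.g-1, which is a limit of the assay and not a number. The phenyl is therefore not required at this position for a reading at the limit, since (1-methylcyclopropyl)methyl, which has no aromatic ring, gives one there too, and replacing the 2-fluorophenyl with it runs an at least 1.3-fold lower number from compound 1 to compound 3 (0.12 log units; that floor lies within the scatter). The step between the phenyl and (1-methylcyclopropyl)methyl themselves cannot be read, because compound 2 and compound 3 both stand at the same limit: the limit of < 12 mL.min-1.g-1 in this assay, at which 2 of the 3 values shown sit.

On these data alone, how far under that limit compound 2 and compound 3 actually lie remains open. So does whether this saturated chain carbon would keep a reading at the limit with an amine or a carboxylic acid in the group it carries.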